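The source may hold more compounds than are shown below. What is called first, only, known or untested is meant among the compounds shown, and "the series" means these compounds.

Measured so far in a functional assay on K562 cells (Homo sapiens) for antiproliferative activity, read by MTT assay, with a stated time of 72 h; on this read-out lower numbers stand for stronger inhibition and higher numbers for weaker inhibition:
- compound 1 `COc1cc(C(=O)c2sc3ccccc3c2-c2ccc(Cl)cc2)cc(OC)c1OC`: 4200 nM
- compound 2 `CCOc1ccc(-c2c(C(=O)c3cc(OC)c(OC)c(OC)c3)sc3ccccc23)cc1`: 3100 nM

Among the compounds with values here, compound 2 sits within the scatter of compound 1, the only other compound measured. Within the data shown here, the single step available is a 1.4-fold lower number from compound 1 to compound 2 (0.13 log units; within the scatter), with ethoxy in place of chloro on an aromatic carbon. Compound 3 `CCOc1ccc(Nc2c(C(=O)c3cc(OC)c(OC)c(OC)c3)sc3ccccc23)cc1` differs from compound 2 by (4-ethoxyphenyl)amino in place of 4-ethoxyphenyl on an aromatic carbon. This is (4-ethoxyphenyl)amino in place of 4-ethoxyphenyl on an aromatic carbon. Among the measured compounds shown here, no measured step covers this kind of change, so the guidance is weak and the range must stay wide. The expected step in this assay is modest and uncertain, a 2.1-fold lower number from compound 2 to compound 3 (0.32 log units; beyond the scatter). For compound 3 the estimated value is 1500 nM, with an expected range from 150 nM to 7000 nM.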

Compound 3, half-maximal inhibitory concentration: 200 nM
Compound 3: middle estimate off by 7.5-fold (0.88 log units), on the high side, and the stated range covers the measured number.
By their numbers in this assay, from the lowest: compound 3; then compounds 2 and 1 (each within the scatter of the next).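

In this assay the link to this position matters far more than the earlier change on the outer ring: (4-ethoxyphenyl)amino in place of 4-ethoxyphenyl gives a 16-fold lower number from compound 2 to compound 3 (1.19 log units; beyond the scatter), a large step. Measured against the chloro compound, the change gives a 21-fold lower number from compound 1 to compound 3 (1.32 log units; beyond the scatter), also large. Nothing shown explains this gain.

Going by these compounds, it remains open whether a methylated amine or an ether oxygen as the link would give a similar step. The effect of chloro or a longer alkoxy chain on the outer ring of the amino compound is also unknown.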